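The source may hold more compounds than are shown below. What is called first, only, known or untested is meant among the compounds shown, and "the series" means these compounds.

Measured compounds:
compound 1, `CC/C(=C(/c1ccc(/C=C/C(=O)O)cc1)c1ccc2[nH]ncc2c1)c1ccccc1` — in a functional assay on MCF7 cells (Homo sapiens) for cytotoxicity, read by CellTiter-Glo, with a stated time of 5 days (a higher number here means a weaker inhibitor, a lower number a stronger inhibitor), compound 1 gives 7.2 nM
compound 2, `CCC/C(=C(/c1ccc(/C=C/C(=O)O)cc1)c1ccc2[nH]ncc2c1)c1ccccc1` — in this assay compound 2 gives 11 nM
compound 3, `O=C(O)/C=C/c1ccc(/C(=C(/CCF)c2ccccc2)c2ccc3[nH]ncc3c2)cc1` — in this assay compound 3 gives 2.1 nM

Compound 3 holds the lowest number of the three. The nearest to it is compound 1, as a 3.4-fold lower number from compound 1 to compound 3 (0.54 log units; beyond the scatter) shows, and the furthest is compound 2, as a 5.2-fold lower number from compound 2 to compound 3 (0.72 log units; beyond the scatter) shows. Compound 1 and compound 2 lie close to each other, a 1.5-fold higher number from compound 1 to compound 2 (0.18 log units; within the scatter).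

The compound not yet measured is compound 4, `O=C(O)/C=C/c1ccc(/C(=C(\c2ccccc2)C2CC2)c2ccc3[nH]ncc3c2)cc1`. It differs from compound 3 in one place: cyclopropyl in place of 2-fluoroethyl on a double-bonded chain carbon bound to an aromatic carbon and a double-bonded chain carbon. Among the compounds with values here, none of the measured steps matches this change directly. Within the data shown here, the steps that bear on it are the two that lead into compound 3 from a chain lacking fluorine, a 3.4-fold lower number from compound 1 to compound 3 (0.54 log units; beyond the scatter) and a 5.2-fold lower number from compound 2 to compound 3 (0.72 log units; beyond the scatter): both give a lower number when fluorine enters the saturated chain, and a higher number when it leaves. Compound 4 likewise loses the fluorine, and what replaces the 2-fluoroethyl is a small carbon ring rather than a plain chain, for which no comparison exists here. The expectation is therefore a modest rise in this assay from compound 3 to compound 4, of about the size seen in the steps to compound 3, namely a 3.1-fold higher number from compound 3 to compound 4 (0.49 log units; beyond the scatter). Compound 4 is expected to give 6.5 nM, with a range from 2.5 nM to 18 nM.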

Compound 4, half-maximal inhibitory concentration: 13 nM
Estimate against measurement, compound 4: 2.0-fold (0.30 log units) below; low and high end bracket the measured number.
By their numbers in this assay, from the lowest: compound 3; then compounds 1, 2 and 4 (each within the scatter of the next).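

In this assay, cyclopropyl in place of 2-fluoroethyl on this double-bonded chain carbon gives a 6.2-fold higher number from compound 3 to compound 4 (0.79 log units; beyond the scatter), so the small carbon ring, with the same count of heavy atoms, does not keep the low number that compound 3 holds. Against the plain chains at the same place the ring shows no difference beyond the scatter, with a 1.2-fold higher number from compound 2 to compound 4 (0.07 log units; within the scatter) and a 1.8-fold higher number from compound 1 to compound 4 (0.26 log units; within the scatter), which leaves compound 3, with its fluorine-bearing chain, as the only one of the four that stands apart from the others. Nothing available here explains why cyclopropyl, ethyl and propyl read alike or why 2-fluoroethyl differs from them.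

As far as these compounds go, whether the lower number belongs to fluorine in particular or would also come with 2-chloroethyl or 2-hydroxyethyl at this place remains open. Also open, from the compounds shown here alone, are whether a cyclobutyl ring would read like cyclopropyl, and whether a fluorine placed on the cyclopropyl ring would bring the number of compound 4 closer to that of compound 3.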